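The source may report more compounds than this note shows. Statements on the series, on what has been measured and on what is new or still open speak of the compounds shown alone.

Compound 1 `C1=C(c2cccnc2)C[C@@H]2CNC[C@H]1C2`: 2.3 nM
Compound 2 `CN1CC2C=C(c3ccc(F)nc3)CC(C2)C1`: > 10000 nM, a limit, not a number
Compound 3 `C1=C(c2cncc(Oc3ccccc3)c2)CC2CNCC1C2`: 62 nM

All three come from an in vitro functional assay on SH-EP1 cells for agonist activity at Neuronal acetylcholine receptor; alpha4/beta2 (Homo sapiens), read by FLIPR and calcium flux; on this read-out higher numbers stand for an effect only at larger amounts of compound and lower numbers for an effect already at smaller amounts. Compound 3 gives the highest of the two numbers; compound 1 gives a far lower number, a gap well beyond the usual scatter. The value of compound 2 is a limit, not a number, (the limit of > 10000 nM in this assay, at which 1 of the 3 values shown sits). Compound 4 `COc1cncc(C2=CC3CNCC(C2)C3)c1` differs from compound 3 by methyl in place of phenyl on an oxygen on an aromatic ring. Among the compounds with values here, no pair of measured compounds shows the effect of such a change, so the direction is not settled by a measured step; the group that enters is the smaller one by the count above, and compound 1, which carries no group there at all, gives 2.3 nM. Compound 4 is therefore expected to give 15 nM, within 4 nM to 60 nM, an estimated step of a 4.1-fold lower number from compound 3 to compound 4 (0.62 log units; beyond the scatter) toward lower numbers.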

Compound 4, half-maximal effective concentration: 49 nM
Estimate against measurement, compound 4: 3.3-fold (0.51 log units) below, and the stated range covers the measured number.
By their numbers in this assay, from the lowest: compound 1; then compounds 4 and 3 (each within the scatter of the next). At a limit, above all of these: compound 2.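

Methyl in place of phenyl on an oxygen on an aromatic ring makes no readable difference (a 1.3-fold lower number from compound 3 to compound 4 (0.10 log units; within the scatter)). At this place, then, a single carbon and a six-carbon aromatic ring cannot be told apart on this read-out, at least for these two groups. Neither group brings the number to that of compound 1, which carries no group there and gives 2.3 nM.

On these data alone, what a hydroxyl, an amine or a longer chain such as ethoxy would give at this place stays open. Nothing shown gives a reason why phenoxy and methoxy read alike.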